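The source may hold more compounds than are shown below. What is called first, only, known or untested is meant among the compounds shown, and "the series" means these compounds.

Three compounds have values so far in a functional assay on KB cells (Homo sapiens) for cytotoxicity (on this read-out higher numbers stand for weaker inhibition and lower numbers for stronger inhibition), as follows
- compound 1 `CCOc1ccc2c(c1)C(=O)C=CC2=O` gives 21400 nM
- compound 2 `CS(=O)(=O)Oc1ccc2c(c1)C(=O)C=CC2=O` gives 11600 nM
- compound 3 `CC(=O)Oc1ccc2c(c1)C(=O)C=CC2=O` gives 22100 nM

On these numbers compound 3 cannot be told apart from the other two, as a 1.0-fold higher number from compound 1 to compound 3 (0.01 log units; within the scatter) and a 1.9-fold higher number from compound 2 to compound 3 (0.28 log units; within the scatter) show. Compound 4 `O=C(Oc1ccc2c(c1)C(=O)C=CC2=O)c1ccccc1` is still unmeasured. It differs from compound 3 by phenyl in place of methyl on a carbonyl carbon with phenyl in place of methyl on a carbonyl carbon.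

Among the measured compounds shown here, no measured step makes this exchange, and none of the three compounds brings in a ring at this place, so the evidence is indirect. The closest guide is the exchange of groups on the oxygen on an aromatic ring. Besides the two steps above, a 1.8-fold lower number from compound 1 to compound 2 (0.27 log units; within the scatter) also stays within the scatter. Ethyl, methylsulfonyl and acetyl on that oxygen therefore give values that cannot be separated in this assay and this sets the expectation of no step beyond the scatter, though the larger group leaves the range wide. The estimate is a 1.3-fold lower number from compound 3 to compound 4 (0.11 log units; within the scatter) as the expected step. For compound 4 the estimated value is 17000 nM with 6500 nM to 42000 nM as the expected range.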

Compound 4, half-maximal inhibitory concentration: 12100 nM
Beside the measured number, compound 4's estimate is 1.4-fold (0.15 log units) above it, within the range that was stated.
By their numbers in this assay, from the lowest: compounds 2, 4, 1 and 3 (each within the scatter of the next).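

In this assay, compound 4 is the only compound shown with a ring on this carbonyl carbon, and the exchange of methyl for phenyl gives a 1.8-fold lower number from compound 3 to compound 4 (0.26 log units; within the scatter). The earlier steps shown here compared only ethyl, methylsulfonyl and acetyl on the oxygen on an aromatic ring, so this result adds that going from methyl, with 1 heavy atom, to phenyl, with 6 heavy atoms and one six-membered aromatic ring of carbon only, still does not separate the two compounds in this read-out. No measurement shown here accounts for the absence of a clear change at this place.

The compounds shown leave open whether an amine, a carboxylic acid or a longer chain such as butyl on this carbonyl carbon, or a methoxy or chloro group on the phenyl of compound 4, would stay within the scatter as well. Since every step shown lies within the scatter, it also remains open whether any group at this position can move the value clearly in either direction.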